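The source may report more compounds than this note shows. Statements on the series, on what has been measured and on what is new or still open speak of the compounds shown alone.

Measured compounds in a functional assay on HeLa cells (Homo sapiens) for antiproliferative activity, read by MTT assay, with a stated time of 48 h; a lower number here means a stronger inhibitor, a higher number a weaker inhibitor:
- compound 1 `CCN1CCN(c2nc(Nc3ccc(C(=O)NC4CC(C)(C)N([O])C(C)(C)C4)cc3)ncc2[N+](=O)[O-])CC1` gives 17500 nM
- compound 2 `Cc1cc(Nc2nc(Nc3ccc(C(=O)NC4CC(C)(C)N([O])C(C)(C)C4)cc3)ncc2[N+](=O)[O-])n[nH]1` gives 29100 nM
- compound 3 `CCOC(=O)c1csc(Nc2nc(Nc3ccc(C(=O)NC4CC(C)(C)N([O])C(C)(C)C4)cc3)ncc2[N+](=O)[O-])n1` gives 3790 nM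

Compound 3 stands lowest of these three numbers in this assay: the steps of a 4.6-fold lower number from compound 1 to compound 3 (0.66 log units; beyond the scatter) and a 7.7-fold lower number from compound 2 to compound 3 (0.89 log units; beyond the scatter) both lie beyond the scatter, whereas a 1.7-fold higher number from compound 1 to compound 2 (0.22 log units; within the scatter) does not.

Compound 4 `CCOC(=O)Cc1csc(Nc2nc(Nc3ccc(C(=O)NC4CC(C)(C)N([O])C(C)(C)C4)cc3)ncc2[N+](=O)[O-])n1` differs from compound 3 by (ethoxycarbonyl)methyl in place of ethoxycarbonyl on an aromatic carbon. For the measured compounds named here, no measured step touches this position; the two steps that reach compound 3 exchange the whole substituent on the shared core, and each was only modest. With nothing closer to lean on, the change is expected to give no step beyond the scatter, a 1.2-fold higher number from compound 3 to compound 4 (0.07 log units; within the scatter). Compound 4 is therefore estimated at 4500 nM, within a range from 1500 nM to 13000 nM.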

Compound 4, half-maximal inhibitory concentration: 12000 nM
Compound 4: the middle estimate sits 2.7-fold (0.43 log units) below what was measured; the range from low to high includes it.
By their numbers in this assay, from the lowest: compound 3; then compounds 4, 1 and 2 (each within the scatter of the next, the first and the last beyond it).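

In this assay, (ethoxycarbonyl)methyl in place of ethoxycarbonyl gives a 3.2-fold higher number from compound 3 to compound 4 (0.50 log units; beyond the scatter), so activity at this aromatic carbon next to the ring nitrogen depends on how the ester is attached. The thiazole's edge narrows: a 2.4-fold lower number from compound 2 to compound 4 (0.38 log units; beyond the scatter) stays beyond the scatter, whereas a 1.5-fold lower number from compound 1 to compound 4 (0.16 log units; within the scatter) falls within it, so the lead of compound 3 over the 4-ethylpiperazin-1-yl compound 1 is lost. Nothing available gives a reason for this shift. Still open, as far as these compounds go, is how a carboxylic acid, an amine or a longer ester chain at this carbon would compare with compound 3 and compound 4.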